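Compound 4 and the limits of its neighbours

The compounds below may be only part of what the source reports. "The series", "measured", "known", "first", "only" and "open" are said of these compounds alone.

In a physicochemical assay for solubility (a lower number here means a less soluble compound, a higher number a more soluble compound), compound 3 (`CNC(=O)c1cc(C(=O)NC2CC2)cn(CC2CCCOC2)c1=O`) stands at >= 131 ug/mL, a limit and not a number. Compound 1 (`CNC(=O)c1cc(C(=O)NC2CC2)cn(Cc2ccc(OC)cc2)c1=O`) gives >= 143 ug/mL, also a limit. Compound 2 (`CNC(=O)c1cc(C(=O)NC2CC2)cn(Cc2ccc(F)cc2)c1=O`) gives >= 162 ug/mL, again a limit. Compound 4 (`CNC(=O)c1cc(C(=O)NC2CC2)cn(Cc2cccc3occc23)c1=O`) carries 1-benzofuran-4-yl in place of oxan-3-yl on a saturated chain carbon bound to an aromatic nitrogen. For the measured compounds named here, two measured steps bear on this change, since both end at oxan-3-yl in that place: a step that the two limits leave unreadable from compound 1 to compound 3 and a step that the two limits leave unreadable from compound 2 to compound 3. Neither size can be read, so only a small downward move is expected, with the estimate being an at least 1.0-fold lower number from compound 3 to compound 4 (0.03 log units; that floor lies within the scatter). For compound 4 the estimated solubility is 120 ug/mL, with an expected range of 40 ug/mL to 180 ug/mL.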

Compound 4, solubility: >= 110 ug/mL
Compound 4: a limit, no number (the forecaster's own chance of this, stated with the estimate: 50%); the middle value does not contradict the limit.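

In this assay, for the compounds shown here, compound 4 gives only a limit, as do compound 1, compound 2 and compound 3, and no step to compound 4 can be read. On these data alone, whether these four compounds differ at all in this assay stays open.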